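Step from compound 2 to compound 4: clearance notes

This account rests on a few compounds, and the source may have more. Where it says the series, first, only, none or still open, it means among the compounds named here.

Values in an ADME assay on microsomes from liver (Homo sapiens) for metabolic stability; a lower number here means slower removal, a higher number faster removal of the compound:
- compound 1 `Cc1c(Cc2ccc(-n3cccn3)cc2)cc(C(=O)N[C@H]2CCOC[C@@H]2O)c(=O)n1C`: < 8 mL/min/kg (a limit)
- compound 2 `Cc1c(Cc2ccc(-c3cocn3)cc2)cc(C(=O)N[C@H]2CCCC[C@@H]2O)c(=O)n1C`: 17 mL/min/kg
- compound 3 `Cc1c(Cc2ccc(-c3ccn(C)n3)cc2)cc(C(=O)N[C@H]2CCCC[C@@H]2O)c(=O)n1C`: 13 mL/min/kg

For the measured compounds named here, compound 2 stands level, within the scatter, with the only other numeric value: a 1.3-fold lower number from compound 2 to compound 3 (0.12 log units; within the scatter). Going by the values given here, the value of compound 1 is a limit and gives no step here. Compound 4 `CO[C@@H]1CCN(c2ccc(Cc3cc(C(=O)N[C@H]4CCCC[C@@H]4O)c(=O)n(C)c3C)cc2)C1` is still unmeasured, and its change is 3-methoxypyrrolidin-1-yl in place of 1,3-oxazol-4-yl on an aromatic carbon. A five-membered non-aromatic ring enters where a five-membered aromatic ring leaves. Among the compounds with values here, the one measured step at this place exchanged two aromatic rings, so compound 3 at 13 mL/min/kg bears on this change only loosely. No step beyond the scatter in this assay is expected, and the estimated step is a 1.3-fold higher number from compound 2 to compound 4 (0.11 log units; within the scatter). For compound 4 the expected value is 22 mL/min/kg, with an estimated range of 11 mL/min/kg to 45 mL/min/kg.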

Compound 4, clearance: 22 mL/min/kg
Compound 4: the middle estimate sits on the measured number at the digits printed; the range from low to high includes it.
By their numbers in this assay, from the lowest: compounds 3, 2 and 4 (each within the scatter of the next). At a limit, below all of these: compound 1.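

In this assay, a five-membered non-aromatic ring at this place, para to a large group, gives a 1.3-fold higher number from compound 2 to compound 4 (0.11 log units; within the scatter), and set against the other aromatic ring it gives a 1.7-fold higher number from compound 3 to compound 4 (0.23 log units; within the scatter). This position therefore accepts 3-methoxypyrrolidin-1-yl as well as the two aromatic rings, with no step beyond the scatter. Nothing measured here bears on why these steps are so small.

Open, as far as these compounds go, is whether a carboxylic acid or a pyrrolidin-1-yl ring without the methoxy group would give a step beyond the scatter at this place. From the compounds shown here alone, the effect of the opposite stereocentre in the methoxy-bearing ring also remains open.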